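The source may hold more compounds than are shown below. What is called first, only, known or untested is meant among the compounds shown, and "the series" means these compounds.

Compound 1 `COC(=O)c1ccc(NC(=O)[C@H]2CC=C(CCC=C(C)C)C[C@@H]2c2ccccc2)cc1`: > 23000 nM
Compound 2 `CC(C)=CCCC1=CC[C@H](C(N)=O)[C@@H](c2ccccc2)C1`: > 23000 nM

In an assay on isolated protein for inhibition of Apoptosis regulator Bcl-2 (Homo sapiens), read by fluorescence polarization, with stated times of 5 min and 10 min (a lower number here means a stronger inhibitor, a higher number a weaker inhibitor), compound 1 gives > 23000 nM, which is a limit of the assay rather than a number. In this assay compound 2 gives > 23000 nM, again a limit. The change between them, a step that the two limits leave unreadable from compound 1 to compound 2, cannot be sized, given (the limit of > 23000 nM in this assay, at which 2 of the 2 values shown sit). Compound 3 `CONC(=O)[C@H]1CC=C(CCC=C(C)C)C[C@@H]1c1ccccc1` differs from compound 2 by methoxy in place of hydrogen on an amide-type nitrogen. Among the compounds with values here, no measured step bears on this change, and nothing among the values points towards stronger inhibition, so compound 3 is expected to remain at the limit, an estimated step that the limit leaves unreadable from compound 2 to compound 3. The estimate for compound 3 is 30000 nM, with a range from 8000 nM to 100000 nM.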

Compound 3, inhibition constant: 2400 nM
Beside the measured number, compound 3's estimate is 13-fold (1.10 log units) above it; the measured number lies below the stated range.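

On the amide-type nitrogen, methoxy in place of hydrogen gives an at least 9.5-fold lower number from compound 2 to compound 3 (0.98 log units; beyond the scatter) in this assay, so a change at this position can bring a reading below the limit. Methoxy in place of 4-(methoxycarbonyl)phenyl gives an at least 9.5-fold lower number from compound 1 to compound 3 (0.98 log units; beyond the scatter), and of the three groups shown on this nitrogen, only methoxy gives a reading below the limit. Neither step has a full size, as one end of each is a limit: the limit of > 23000 nM in this assay, at which 2 of the 3 values shown sit.

Going by these compounds, it remains open whether a hydroxy, ethoxy or plain methyl group on this nitrogen would match methoxy, and so whether the oxygen atom or the added carbon matters.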